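Swapping the Attachment Point of an Aromatic Group

This account rests on a few compounds, and the source may have more. Where it says the series, first, only, none or still open, it means among the compounds named here.

Of the compounds shown here, two have so far been tested in a functional assay on MDA-MB-231 cells (Homo sapiens) for antiproliferative activity, read by MTT assay, with a stated time of 48 h; on this read-out lower numbers stand for stronger inhibition and higher numbers for weaker inhibition. Compound 1 `O=C(N[C@H]1C[C@@H](C(=O)NO)N(S(=O)(=O)c2ccc(Oc3ccccc3)cc2)C1)c1ccc2no[n+]([O-])c2c1` gives 7010 nM, and compound 2 `COc1ccc(/C=C/C(=O)N2C[C@@H](NC(=O)c3ccc4no[n+]([O-])c4c3)C[C@H]2C(=O)NO)cc1OC` gives 9810 nM; compound 2 shows the higher of the two numbers, but its gap to compound 1 lies within the scatter. Compound 3 `COc1ccc(/C=C/C(=O)N2C[C@@H](NC(=O)c3cccc4no[n+]([O-])c34)C[C@H]2C(=O)NO)cc1OC` differs from compound 2 by a group of 10 heavy atoms (6 carbon, 2 nitrogen, 2 oxygen; one five-membered aromatic ring with 3 hetero atoms, one six-membered aromatic ring of carbon only) in place of a group of 10 heavy atoms (6 carbon, 2 nitrogen, 2 oxygen; one five-membered aromatic ring with 3 hetero atoms, one six-membered aromatic ring of carbon only), on a carbonyl carbon; the two have the same atoms, joined differently. Going by the values given here, no measured pair shows a change of this kind, so only a step within the scatter, in either direction, is expected: a 1.0-fold higher number from compound 2 to compound 3 (0.01 log units; within the scatter). Compound 3 is accordingly estimated at 10000 nM, somewhere between 3500 nM and 30000 nM.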

Compound 3, half-maximal inhibitory concentration: 16500 nM
Compound 3: the middle estimate sits 1.7-fold (0.22 log units) below what was measured; the range from low to high includes it.
By their numbers in this assay, from the lowest: compounds 1, 2 and 3 (each within the scatter of the next, the first and the last beyond it).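

Going by these compounds alone, this is the first pair that changes only where the aromatic group joins the carbonyl carbon, with the same atoms joined differently. In this assay, this gives a 1.7-fold higher number from compound 2 to compound 3 (0.23 log units; within the scatter), so at this position the change of attachment point has no effect that can be told from the scatter. No supporting measurement is available to explain this result. From the compounds shown here alone, it remains open whether an amine or a carboxylic acid on this carbonyl carbon would shift the number beyond the scatter. The same swap on compound 1 is also an open question.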